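Bromopyrrole chalcones: hydroxy removal on the phenyl ring

This account rests on a few compounds, and the source may have more. Where it says the series, first, only, none or still open, it means among the compounds named here.

Measured so far in a functional assay on MCF7 cells (Homo sapiens) for cytotoxicity, read by MTT assay, with stated times of 6 h and 48 h; on this read-out lower numbers stand for stronger inhibition and higher numbers for weaker inhibition:
- compound 1 `Cn1c(/C=C/C(=O)c2ccccc2)cc(Br)c1Br`: 35400 nM
- compound 2 `Cn1c(/C=C/C(=O)c2ccc(O)cc2)cc(Br)c1Br`: 3120 nM
- compound 3 `O=C(/C=C/c1cc(Br)c(Br)[nH]1)c1ccccc1O`: 1490 nM

Compound 3 stands lowest of the three, with compound 2 nearest and compound 1 furthest. The difference between the core of compound 3 and the core of compound 2 is not broken down here.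

One change has already been seen once within the set. From compound 2 to compound 1 it is hydrogen in place of hydroxy on an aromatic carbon and it gave an 11-fold higher number from compound 2 to compound 1 (1.05 log units; beyond the scatter).

Compound 4 `O=C(/C=C/c1cc(Br)c(Br)[nH]1)c1ccccc1` is not yet measured in this assay. From compound 3 to compound 4 the change is hydrogen in place of hydroxy on an aromatic carbon. Within the data shown here, it is the same kind of change as the one from compound 2 to compound 1, but not the same: in compound 2 the hydroxy sits para to a large group, in compound 3 ortho to a large group. Whether the position alters the size of the step cannot be read from the compounds at hand, since the change has only occurred once in a measured pair.

For compound 4 a step of a 10-fold higher number from compound 3 to compound 4 (1.00 log units; beyond the scatter) in this assay is expected, resting on the step from compound 2 to compound 1, an 11-fold higher number from compound 2 to compound 1 (1.05 log units; beyond the scatter), and on the starting value of compound 3, 1490 nM, with a wider range allowed for the different place of the hydroxy. Compound 4 is therefore estimated at 15000 nM, in the range 5000 nM to 45000 nM.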

Compound 4, half-maximal inhibitory concentration: 12200 nM
Compound 4: middle estimate off by 1.2-fold (0.09 log units), on the high side; measured number inside the range.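

In this assay, hydrogen in place of hydroxy gives an 8.2-fold higher number from compound 3 to compound 4 (0.91 log units; beyond the scatter), and this step agrees with the one seen earlier on the other core: the same change on two cores in this assay, an 11-fold higher number (1.05 log units; beyond the scatter) from compound 2 to compound 1 and an 8.2-fold higher number (0.91 log units; beyond the scatter) from compound 3 to compound 4, 1.4-fold (0.14 log units) apart, within the scatter of two such steps The change therefore carries across the two cores shown with a similar size, although the hydroxy stands ortho to a large group only in compound 3 and at another place in compound 2. This does not separate the effect of position from that of the core, since compound 2 and compound 3 differ in both, and two pairs do not establish a rule for the series; the other single-place comparison, hydrogen in place of methyl on an aromatic nitrogen, gives a 2.9-fold lower number from compound 1 to compound 4 (0.46 log units; beyond the scatter), but it has been seen only without the hydroxy, so its size with a hydroxy present cannot be read.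

Still open, as far as these compounds go, is whether a hydroxy moved to another place on the same core gives a step of the same size, and whether a methoxy, an amine or a carboxylic acid in that place behaves like the hydroxy. Also open, from the compounds shown here alone, is how a longer chain, such as ethyl, on the aromatic nitrogen compares with methyl and hydrogen.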